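Urea-to-amide change at the carbonyl of compound 2

The source may hold more compounds than are shown below. What is called first, only, known or untested is meant among the compounds shown, and "the series" means these compounds.

In a functional assay on HCT-116 cells (Homo sapiens) for inhibition, read by sulforhodamine B assay, with a stated time of 48 h (on this read-out higher numbers stand for weaker inhibition and lower numbers for stronger inhibition), compound 2 `COc1cc(Cl)cc(-c2nn(-c3cccc(NC(=O)Nc4ccc(Cl)c(Cl)c4)c3)cc2-c2ccncc2)c1` gives 2020 nM, the highest of the two numbers seen so far. Among the compounds with values here, compound 1 `O=C(Nc1cccc(-n2cc(-c3ccncc3)c(-c3cc(O)cc(Cl)c3)n2)c1)Nc1ccc(Cl)c(Cl)c1` gives 1740 nM in this assay, and the only measured step, a 1.2-fold higher number from compound 1 to compound 2 (0.06 log units; within the scatter), concerns the oxygen on the aromatic ring and not the carbonyl. Compound 3 `COc1cc(Cl)cc(-c2nn(-c3cccc(NC(=O)c4cccc(C(F)(F)F)c4)c3)cc2-c2ccncc2)c1` carries 3-(trifluoromethyl)phenyl in place of (3,4-dichlorophenyl)amino on a carbonyl carbon. Within the data shown here, no measured step bears on this change, so the expectation rests on no precedent and the range is kept wide. Compound 3 is estimated at 3000 nM, between 700 nM and 13000 nM. The expected step is a 1.5-fold higher number from compound 2 to compound 3 (0.17 log units; within the scatter), direction uncertain.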

Compound 3, half-maximal inhibitory concentration: 3170 nM
Beside the measured number, compound 3's estimate is 1.1-fold (0.02 log units) below it; the measured number falls inside the stated range.
By their numbers in this assay, from the lowest: compounds 1, 2 and 3 (each within the scatter of the next).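

In this assay, within the data shown here, 3-(trifluoromethyl)phenyl in place of (3,4-dichlorophenyl)amino on a carbonyl carbon gives a 1.6-fold higher number from compound 2 to compound 3 (0.20 log units; within the scatter), the first reading at this position: the urea and the amide stay within the scatter, although the leaving group carries a hydrogen-bond donor and the entering group none. The amide-type nitrogen and the ring substituents change together, so this single step does not separate them. No measurement at hand explains the result.

Open, on these data alone, is how the amide of the 3,4-dichlorophenyl ring, or the urea of the 3-(trifluoromethyl)phenyl ring, would read. Also open, as far as these compounds go, is whether a carboxylic acid or a longer alkyl chain on this carbonyl carbon would stay within the scatter.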